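Notes on the shared core: neopentyl to isopropyl

The source may hold more compounds than are shown below. What is called first, only, known or untested is meant among the compounds shown, and "the series" means these compounds.

Measured so far:
compound 1 `CCC(CC)n1c(-c2ccc(OCc3c(-c4c(Cl)cccc4Cl)noc3C(C)C)cc2F)nc2ccc(C(=O)O)cc21`: > 10000 nM
compound 2 `CC(C)c1onc(-c2c(Cl)cccc2Cl)c1COc1ccc(-c2nc3ccc(C(=O)O)cc3n2CC(C)(C)C)cc1`: 861 nM
compound 3 `CC(C)c1onc(-c2c(Cl)cccc2Cl)c1COc1ccc(-c2nc3ccc(C(=O)O)cc3n2C)c(Cl)c1`: 3520 nM

The read-out throughout is an assay on HEK-293T cells for antagonist activity at vitamin D3 receptor (Homo sapiens), read by a luciferase reporter, with a stated time of 24 h; on this read-out higher numbers stand for weaker inhibition and lower numbers for stronger inhibition. For compound 1 the value > 10000 nM is a limit of the assay and not a number; one of the three values shown sits at the limit of > 10000 nM in this assay, at which 1 of the 3 values shown sits. Compound 2 holds the lowest of the two numbers in this assay, with 861 nM. Among the compounds with values here, compound 3 differs from compound 2 in several places, so no single step connects them. Compound 3 gives 3520 nM, and the gap between the numbers of compound 2 and compound 3 lies beyond the scatter, so only the two values are noted.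

Compound 4 `CC(C)c1onc(-c2c(Cl)cccc2Cl)c1COc1ccc(-c2nc3ccc(C(=O)O)cc3n2C(C)C)cc1` has not been measured. Relative to compound 2 it changes as follows: isopropyl in place of neopentyl on an aromatic nitrogen. The shorter chain replaces the longer one on the same aromatic nitrogen. Within the data shown here, no measured step in the set isolates a change of this kind, so the expectation rests on little beyond the value of compound 2. The expected step is a 1.7-fold higher number from compound 2 to compound 4 (0.24 log units; within the scatter), a modest weakening that may well fall inside the scatter. Compound 4 is estimated at 1500 nM, with a range from 500 nM to 5000 nM.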

Compound 4, half-maximal inhibitory concentration: 3550 nM
Estimate against measurement, compound 4: 2.4-fold (0.37 log units) below; low and high end bracket the measured number.
By their numbers in this assay, from the lowest: compound 2; then compounds 3 and 4 (each within the scatter of the next). At a limit, above all of these: compound 1.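

In this assay the change from neopentyl to isopropyl on the aromatic nitrogen gives a 4.1-fold higher number from compound 2 to compound 4 (0.62 log units; beyond the scatter) and is the first step in the series that differs in one place only, so this position is shown not to be indifferent to the group it carries. The finding covers this one pair: with only neopentyl and isopropyl compared directly, no general trend with chain length or branching can be claimed. Nothing in the data shown accounts for the size of this step.

As far as these compounds go, it remains open whether ethyl, cyclopropyl or a longer chain such as n-hexyl on the same aromatic nitrogen would give a number closer to that of compound 2 or compound 4, and how a chain ending in an amine or a hydroxyl group would read out. Compound 1 and compound 3 each differ from compound 2 in more than one place, so the separate contributions of their fluoro and chloro groups and of their groups on the aromatic nitrogen cannot be read.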